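The source may report more compounds than this note shows. Statements on the series, on what has been measured and on what is new or still open speak of the compounds shown alone.

Compound 1 `O=C(O)CNC(=O)COc1ccc([C@H]2CC[C@]3(CC2)OOC2(O3)C3CC4CC(C3)CC2C4)cc1`: 12.5 ug/mL in a physicochemical assay for solubility, read by nephelometry, in phosphate buffer, measured as kinetic solubility, with a stated time of 30 min, at pH 6.5; on this read-out higher numbers stand for higher solubility and lower numbers for lower solubility.
Compound 2 `O=C(O)c1cccc([C@H]2CC[C@]3(CC2)OOC2(O3)C3CC4CC(C3)CC2C4)c1`: a limit only, < 1.6 ug/mL.

In this assay, among the compounds with values here, compound 1 holds the only real number. The result for compound 2 is a limit, not a number (the limit of < 1.6 ug/mL in this assay, at which 1 of the 2 values shown sits). Compound 3 `CC(C)(Oc1ccc([C@H]2CC[C@]3(CC2)OOC2(O3)C3CC4CC(C3)CC2C4)cc1)C(=O)O` has not been measured. It differs from compound 1 in one place: 1-carboxy-1-methylethyl in place of ((carboxymethyl)carbamoyl)methyl on an oxygen on an aromatic ring. Within the data shown here, no two measured compounds differ in a single spot, so no measured step guides this change. The expected step is downward, a loss of solubility beyond the usual scatter, a 3.1-fold lower number from compound 1 to compound 3 (0.49 log units; beyond the scatter). Compound 3 is expected to give 4 ug/mL, within a range from 1.6 ug/mL to 12 ug/mL, with a fair chance that only a limit is reported.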

Compound 3, solubility: < 1.6 ug/mL
Compound 3: only a limit was reported; the forecaster's own chance of this, stated with the estimate: 30%; middle value at least 2.5-fold (0.39 log units) from the limit.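

In this assay, within the data shown here, putting 1-carboxy-1-methylethyl in place of ((carboxymethyl)carbamoyl)methyl on the oxygen on the aromatic ring gives the first step that can be read at this position, an at least 7.8-fold lower number from compound 1 to compound 3 (0.89 log units; beyond the scatter). The group on this oxygen therefore matters to the read-out, and the size printed is a minimum. Compound 3 gives a limit, not a number: the limit of < 1.6 ug/mL in this assay, at which 2 of the 3 values shown sit.

From the compounds shown here alone, the whole group changes in one step, so the share of the amide and of the added methyl groups stays open. Going by these compounds, whether an amine or a longer chain ending in a carboxylic acid on this oxygen would hold the level of compound 1 also stays open.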